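The source may report more compounds than this note shows. Statements on the series, on what has been measured and on what is new or still open speak of the compounds shown alone.

Measured so far:
compound 1, `CCOc1cc(=O)oc2cc(OCc3cccc(F)c3)ccc12`, 25% in an assay on isolated protein (strain Sprague-Dawley) for inhibition of Amine oxidase [flavin-containing] A (Rattus norvegicus), read by spectrophotometry, with a stated time of 5 min, tested at 10 uM; a higher number here means more inhibition at the concentration tested (going by the name of the read-out), a lower number less inhibition;
compound 2, `CCOc1cc(=O)oc2cc(OCc3cccc(Cl)c3)ccc12`, 2%.

Compound 2 stands lowest of the two numbers; the nearest, compound 1, lies higher by a number 23 percentage points lower from compound 1 to compound 2 (beyond the scatter). Compound 3, `COCOc1cc(=O)oc2cc(OCc3cccc(Cl)c3)ccc12`, has not yet been measured. It differs from compound 2 by methoxy in place of methyl on a saturated chain carbon bound to an oxygen on an aromatic ring. Among the measured compounds shown here, no measured step touches this part of the molecule: the only step known, from compound 1 to compound 2, concerns the aromatic carbon and not the chain bound to the ring oxygen. Given the low starting point of compound 2, compound 3 is expected to shift by a number 3 percentage points higher from compound 2 to compound 3 (within the scatter), not beyond the scatter. Compound 3 is estimated at 5%, within 0% to 20%.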

Compound 3, a percentage reported as inhibition, at one concentration (the size of the read-out at that concentration, not a potency): 23%
Beside the measured number, compound 3's estimate is 18 percentage points below it, and the stated range ends below it.
By their numbers in this assay, from the lowest: compound 2; then compounds 3 and 1 (each within the scatter of the next).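

In this assay, methoxy in place of methyl on a saturated chain carbon bound to an oxygen on an aromatic ring gives a number 21 percentage points higher from compound 2 to compound 3 (beyond the scatter), a step beyond the scatter. This shows that the chain on the ring oxygen, which the earlier step left untouched, can also change the read-out, at least with the chloro group of compound 2 in place. No available evidence bears on why this step occurs. Still open, from the compounds shown here alone, is whether the same change would have a similar effect with the fluoro group of compound 1, and how an amine or a longer chain would fare at this position.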